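A few compounds are considered here, and "the series" means these few. Any claim that something is new, unique, unknown or untested is made for them only; others in the source may bear on it.

Measured in an ADME assay on microsomes from liver (Homo sapiens) for metabolic stability; on this read-out lower numbers stand for slow clearance and higher numbers for fast clearance:
- Compound 1 `Cc1ccc2[nH]c(C(=O)N[C@H]3CN(S(=O)(=O)c4ccccc4)C[C@@H]3C(=O)NC[C@H]3CCCN3)cc2c1`: < 3 mL.min-1.g-1
- Compound 2 `Cc1ccc2[nH]c(C(=O)N[C@H]3CN(S(=O)(=O)c4ccccc4)C[C@@H]3C(=O)NC[C@@H]3CCCN3C)cc2c1`: 31 mL.min-1.g-1

The value of compound 1 is a limit of the assay.

Among the compounds with values here, compound 2 holds the only actual number in this assay, at 31 mL.min-1.g-1.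

Compound 3 `Cc1ccc2[nH]c(C(=O)N[C@H]3CN(S(=O)(=O)c4ccccc4)C[C@@H]3C(=O)NC[C@H]3CCCN3C)cc2c1` relates to compound 2 as follows: the two compounds have the same atoms and bonds and differ only in configuration as drawn: 1 of 3 stereo elements differ; a stereocentre at a saturated ring carbon is drawn S in compound 2 and R in compound 3. Within the data shown here, the one measured step, an at least 10-fold higher number from compound 1 to compound 2 (1.01 log units; beyond the scatter), is large, but it concerns 1-methylpyrrolidin-2-yl in place of pyrrolidin-2-yl, and that group stays in compound 3. Among the measured compounds shown here, no measured step tests a change of configuration, so no step beyond the scatter is expected in this assay. The expected step is a 1.1-fold lower number from compound 2 to compound 3 (0.04 log units; within the scatter). For compound 3 the estimated value is 28 mL.min-1.g-1, with an expected range from 12 mL.min-1.g-1 to 60 mL.min-1.g-1.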

Compound 3, intrinsic clearance in microsomes in the Homo sapiens assay: 22 mL.min-1.g-1
Estimate against measurement, compound 3: 1.3-fold (0.10 log units) above; the measured number falls inside the stated range.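

In the Homo sapiens assay, inverting the stereocentre at the saturated ring carbon gives a 1.4-fold lower number from compound 2 to compound 3 (0.15 log units; within the scatter), and in a physicochemical assay for lipophilicity, measured as octanol-water partition, at pH 7.4 (a lower number here means a more polar compound, a higher number a more lipophilic compound), the same change gives no change at the digits printed from compound 2 to compound 3 (within the scatter). In the physicochemical assay compound 2 gives 2.3 and compound 3 gives 2.3. With the configuration now tested, the Homo sapiens assay shows that the methyl group also brings a rise in the second configuration: an at least 7.3-fold higher number from compound 1 to compound 3 (0.86 log units; beyond the scatter), for methyl in place of hydrogen on an amine nitrogen in a ring. Compound 1 stands at a limit of the assay, so the size of this step is only a bound: the limit of < 3 mL.min-1.g-1 in the Homo sapiens assay, at which 1 of the 3 values shown sits.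

Going by these compounds, what an ethyl or acetyl group on that ring nitrogen would do in the Homo sapiens assay stays open. On these data alone, the actual number for compound 1 stays open too.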